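Inverting One Ring Stereocentre Ahead of a Cytotoxicity Test

The source may report more compounds than this note shows. Statements on the series, on what has been measured and on what is new or still open speak of the compounds shown alone.

Compound 1 `CO[C@@H]1[C@@H](OC)[C@H](c2ccccc2)O[C@@H]2CO[C@@H](c3ccccc3)O[C@@H]12` in a functional assay on HEL cells (Homo sapiens) for cytotoxicity (on this read-out higher numbers stand for lower toxicity in this test and lower numbers for higher toxicity in this test), is recorded only as "not determined" (no result reported), so it cannot be placed on any number; the same holds for compound 3 `COc1ccc([C@@H]2OC[C@H]3O[C@@H](c4ccccc4)[C@H](OC)[C@@H](OC)[C@@H]3O2)cc1`, for which the entry is likewise "not determined" (no result reported). Among the compounds with values here, the only measured member of the group is compound 2 `CO[C@@H]1[C@@H](OC)[C@H](c2ccccc2)O[C@@H]2CO[C@@H](C3CCCCC3)O[C@@H]12`, which in this assay gives 20 ug/mL. Compound 4 `CO[C@H]1[C@H]2O[C@H](c3ccccc3)OC[C@H]2O[C@@H](c2ccccc2)[C@@H]1OC` is the next to be tested. It is related to compound 1 by a single change: the two compounds have the same atoms and bonds and differ only in configuration as drawn: 1 of 6 stereo elements differ; a stereocentre at a saturated ring carbon is drawn R in compound 1 and S in compound 4. Within the data shown here, no pair of measured compounds shows what such a change does here, so no step size can be read from the data; the expectation is that compound 4 lands near the one measured value, with no shift beyond the usual scatter assumed. Compound 4 is estimated to give 20 ug/mL in this assay, within a range of 4 ug/mL to 100 ug/mL.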

Compound 4, minimum cytotoxic concentration: > 400 ug/mL
Compound 4 was reported as a limit; the forecaster's own chance of this, stated with the estimate: 40%; at least 20-fold (1.30 log units) between middle value and limit.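

In this assay compound 4 gives > 400 ug/mL, a limit rather than a number. Compound 1 has no single number, so no step can be read between compound 1 and compound 4. The compounds shown leave open what inverting this one stereocentre does to the read-out.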